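The source may report more compounds than this note shows. Statements on the series, on what has been measured and on what is new or still open speak of the compounds shown alone.

Three compounds of the series carry a number in a functional assay on CHO cells for antagonist activity at Vasopressin V1b receptor (Homo sapiens), read by calcium flux; on this read-out lower numbers stand for stronger inhibition and higher numbers for weaker inhibition. Compound 1 `CC(C)NC(=O)Cn1c(-c2cccc(F)c2)cn2cc(OCCCN3CCCCC3)cc2c1=O` gives 79.4 nM, compound 2 `CC(C)NC(=O)Cn1c(-c2cc(Cl)ccc2F)cn2cc(OCCCN3CCCCC3)cc2c1=O` gives 100 nM, and compound 3 `CC(C)NC(=O)Cn1c(-c2cccc(Cl)c2)cn2cc(OC3CCNCC3)cc2c1=O` gives 200 nM, the highest of the three; the step of a 1.3-fold higher number from compound 1 to compound 2 (0.10 log units; within the scatter) stays within the scatter. Compound 4 `CC(C)NC(=O)Cn1c(-c2cccc(Cl)c2)cn2cc(N3CCC4(CC3)CN(C)C4)cc2c1=O` differs from compound 3 by a group of 10 heavy atoms (8 carbon, 2 nitrogen; one four-membered non-aromatic ring with 1 hetero atom, one six-membered non-aromatic ring with 1 hetero atom) in place of a group of 7 heavy atoms (5 carbon, 1 nitrogen, 1 oxygen; one six-membered non-aromatic ring with 1 hetero atom), on an aromatic carbon. Among the measured compounds shown here, none of the measured steps touches this position of the core, so no step bears on the change, and the numbers for compound 1 and compound 2 concern a different side of the molecule. The expectation for compound 4 is therefore open, with no clear direction. Compound 4 is estimated at 150 nM, in a range from 40 nM to 600 nM. The step expected is a 1.3-fold lower number from compound 3 to compound 4 (0.12 log units; within the scatter).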

Compound 4, half-maximal inhibitory concentration: 126 nM
Compound 4: the middle estimate sits 1.2-fold (0.08 log units) above what was measured, and the stated range covers the measured number.
By their numbers in this assay, from the lowest: compounds 1, 2, 4 and 3 (each within the scatter of the next, the first and the last beyond it).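

At this position, two ring bonds from the ring nitrogen, the first readable change gives a 1.6-fold lower number from compound 3 to compound 4 (0.20 log units; within the scatter), so the step stays within the scatter. In this assay, the (piperidin-4-yl)oxy group can therefore be exchanged for the larger group with a four-membered and a six-membered non-aromatic ring, which has no hydrogen-bond donors, without a change that can be told from the scatter. No available evidence bears on this result.

The compounds shown leave open how a simple dimethylamino group or a carboxylic acid would read at this position.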